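Moving from pyridin-2-yl to 2-fluorophenyl on the ring nitrogen

The source may hold more compounds than are shown below. What is called first, only, known or untested is meant among the compounds shown, and "the series" means these compounds.

In an ADME assay on microsomes from liver (Canis lupus familiaris) for metabolic stability, read by LC-MS, using NADPH, with a stated time of 10 min, tested at 0.1 uM (on this read-out lower numbers stand for slow clearance and higher numbers for fast clearance), compound 1 (`COc1ccc(F)cc1N1C(=O)CSC1c1cccc(C(=O)NCCCCc2ccccc2)c1`) gives 1650 mL.min-1.g-1. Compound 2 (`O=C(NCCCCc1ccccc1)c1cccc(C2SCC(=O)N2c2ccccn2)c1`) gives 492 mL.min-1.g-1, the lower of the two numbers, and the gap between them lies beyond the scatter. Compound 3 (`O=C(NCCCCc1ccccc1)c1cccc(C2SCC(=O)N2c2ccccc2F)c1`) has not yet been measured. It differs from compound 2 in a single place, with 2-fluorophenyl in place of pyridin-2-yl on an amide-type nitrogen in a ring.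

Within the data shown here, only one measured step bears on this change, a 3.4-fold lower number from compound 1 to compound 2 (0.53 log units; beyond the scatter), which exchanged a 5-fluoro-2-methoxyphenyl group for the same pyridin-2-yl at that place. The new compound again carries a fluorinated phenyl group there, though without the methoxy group, so part of that modest step is expected to be reversed. Among the measured compounds shown here, this remains a judgement from a single pair, since no measured compound carries 2-fluorophenyl. The expected change in this assay is a 2.0-fold higher number from compound 2 to compound 3 (0.31 log units; beyond the scatter), towards faster clearance. For compound 3 the estimated value is 1000 mL.min-1.g-1, with an expected range of 500 mL.min-1.g-1 to 2000 mL.min-1.g-1.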

Compound 3, intrinsic clearance in microsomes: 815 mL.min-1.g-1
For compound 3 the middle estimate is 1.2-fold (0.09 log units) above the measured one; the range from low to high includes it.
By their numbers in this assay, from the lowest: compounds 2 and 3 (each within the scatter of the next); then compound 1.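

In this assay, 2-fluorophenyl in place of pyridin-2-yl on the amide-type nitrogen gives a 1.7-fold higher number from compound 2 to compound 3 (0.22 log units; within the scatter), so this read-out does not separate compound 2 from compound 3, although one group has a hetero atom in its ring and the other has a ring of carbon only. Exchanging 5-fluoro-2-methoxyphenyl for 2-fluorophenyl gives a 2.0-fold lower number from compound 1 to compound 3 (0.31 log units; beyond the scatter), and this sits alongside the earlier 3.4-fold lower number from compound 1 to compound 2 (0.53 log units; beyond the scatter), so among these three compounds a number beyond the scatter from that of compound 1 does not depend on a ring nitrogen in the group at this place. Nothing given here accounts for these differences between the groups.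

The compounds shown leave open whether the methoxy group or the 5-fluoro substituent of compound 1 goes with its higher number, as neither an unsubstituted phenyl nor a 2-methoxyphenyl group appears at this place. They also leave open how a group bearing an amine or a carboxylic acid would read at this position, and whether a shorter chain on the amide of the shared core would change these numbers.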